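Trifluoromethyl in place of cyclopropyl on the ring of compound 3

The compounds below may be only part of what the source reports. "The series", "measured", "known", "first", "only" and "open" are said of these compounds alone.

Compound 1 `Fc1ccc2nc(-c3ccnnc3)n(C3CC3)c2c1` is measured in an ADME assay on cells for inhibition of cytochrome P450 11B1, mitochondrial (Homo sapiens), read by HPLC, with a stated time of 60 min (a higher number here means a weaker inhibitor, a lower number a stronger inhibitor), where compound 1 gives a limit of the assay, > 10000 nM. Compound 2 `Fc1cc2nc(-c3cncnc3)n(C3CC3)c2cc1F` gives 2270 nM in this assay. Compound 3 `Fc1cc2nc(-c3cncnc3C3CC3)n(C3CC3)c2cc1F` gives a limit of the assay in this assay, > 10000 nM. Among the measured compounds shown here, the step of an at least 4.4-fold higher number from compound 2 to compound 3 (0.64 log units; beyond the scatter) is the only measured change at the carbon that carries the cyclopropyl. Compound 3 therefore stands at the limit of > 10000 nM in this assay, at which 2 of the 3 values shown sit, with no number of its own, so any step from it can only be stated from that limit.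

Compound 4 `Fc1cc2nc(-c3cncnc3C(F)(F)F)n(C3CC3)c2cc1F` differs from compound 3 by trifluoromethyl in place of cyclopropyl on an aromatic carbon. For the measured compounds named here, no measured pair shows this exact exchange; the only step that bears on the same position is an at least 4.4-fold higher number from compound 2 to compound 3 (0.64 log units; beyond the scatter), which already moved the number to the limit once a large group was placed there. A second large group at the same carbon gives no reason to expect a return toward the number of compound 2, so the expected outcome for compound 4 is a value at or near the same limit in this assay, with the step of a number no higher from compound 3 to compound 4 (the limit leaves the size open) expected to lie within the scatter. The estimate for compound 4 in this assay is 10000 nM, expected to fall between 3000 nM and 30000 nM.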

Compound 4, half-maximal inhibitory concentration: 4770 nM
Beside the measured number, compound 4's estimate is 2.1-fold (0.32 log units) above it; low and high end bracket the measured number.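

In this assay, the carbon that carries the cyclopropyl in compound 3 does not give the same reading for every large group: the exchange for trifluoromethyl gives an at least 2.0-fold lower number from compound 3 to compound 4 (0.32 log units; beyond the scatter), so the identity of the group matters here, and not only the loss of the hydrogen of compound 2. Trifluoromethyl does not restore the reading with hydrogen, as the comparison gives a 2.1-fold higher number from compound 2 to compound 4 (0.32 log units; beyond the scatter), and with an at least 4.4-fold higher number from compound 2 to compound 3 (0.64 log units; beyond the scatter) both groups shown at this carbon move the number in the same direction from compound 2. The gap between cyclopropyl and trifluoromethyl is only a lower bound, and the cyclopropyl side has no number of its own: the limit of > 10000 nM in this assay, at which 2 of the 4 values shown sit.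

The compounds shown leave open how a smaller group at this carbon, such as methyl or a single fluorine atom, or a group such as an amine, would read against the hydrogen of compound 2. Also open, on these data alone, is whether the order of hydrogen and trifluoromethyl at this carbon would hold if a methyl or a longer chain replaced the cyclopropyl on the shared core.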